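Trimming an aryl ether to a methyl ether

The source may report more compounds than this note shows. Statements on the series, on what has been measured and on what is new or still open speak of the compounds shown alone.

The series rests on two measured compounds. Compound 1 `CN1CC2C=C(c3ccc(Cl)nc3)CC(C2)C1` gives 22 nM in an in vitro assay on SH-EP1 cells for displacement of a labelled ligand from Neuronal acetylcholine receptor; alpha4/beta2 (Homo sapiens); on this read-out lower numbers stand for stronger inhibition and higher numbers for weaker inhibition. Compound 2 `Fc1ccc(Oc2cncc(C3=CC4CNCC(C3)C4)c2)cc1` gives 0.6 nM in this assay, the lowest number of the two and a gap to compound 1 that lies beyond the usual scatter. The unmeasured compound 3 `COc1cncc(C2=CC3CNCC(C2)C3)c1` differs from compound 2 in one place: methyl in place of 4-fluorophenyl on an oxygen on an aromatic ring. Because compound 2 reaches 0.6 nM with the larger group on the oxygen, the author expects that shrinking it to methyl will cost affinity, with a step from compound 2 to compound 3 of a 17-fold higher number from compound 2 to compound 3 (1.22 log units; beyond the scatter) in this assay, a weakening that should exceed the scatter. For compound 3 the expected value in this assay is 10 nM, estimated to fall between 3 nM and 40 nM.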

Compound 3, inhibition constant: 0.3 nM
Beside the measured number, compound 3's estimate is 33-fold (1.52 log units) above it, and the stated range ends above it.
By their numbers in this assay, from the lowest: compounds 3 and 2 (each within the scatter of the next); then compound 1.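

In this assay the exchange of 4-fluorophenyl for methyl on an oxygen on an aromatic ring gives a 2.0-fold lower number from compound 2 to compound 3 (0.30 log units; within the scatter) and so leaves the two compounds level on this read-out. The 7 heavy atoms of the 4-fluorophenyl, with their six-membered aromatic ring, are therefore not required for a number of this order, since a single methyl carbon on the same oxygen does as well. Compound 2 alone could not show this, as it gave no measure of how much its value depended on the aryl group.

No measured property bears on why the two groups match. The compounds shown leave open how an ethyl, a benzyl or a hydroxyl in this place would read, and whether an amine could take the place of the ether oxygen.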